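A few compounds are considered here, and "the series" means these few. Any claim that something is new, unique, unknown or untested is made for them only; others in the source may bear on it.

Measured in an assay on CHO cells for inhibition of 3-oxo-5-alpha-steroid 4-dehydrogenase 2 (Homo sapiens); a lower number here means a stronger inhibitor, a higher number a weaker inhibitor: compound 1 `Cc1ccc(C(=O)c2ccc(C(=O)c3ccc(C(=O)O)cc3)cc2)cc1` gives 10 nM; compound 2 `O=C(O)c1ccc(C(=O)c2ccc(C(=O)c3ccc(C(=O)O)cc3)cc2)cc1` gives 1000 nM; compound 3 `O=C(O)c1ccc(C(=O)c2ccc(C(=O)c3ccccc3)cc2)cc1` gives 40 nM.

Compound 3 thus stands second of the three numbers, set apart by a 4.0-fold higher number from compound 1 to compound 3 (0.60 log units; beyond the scatter) and by a 25-fold lower number from compound 2 to compound 3 (1.40 log units; beyond the scatter). Compound 4 `O=C(O)c1ccc(C(=O)c2ccc(C(=O)c3ccc(O)cc3)cc2)cc1` differs from compound 3 by hydroxy in place of hydrogen on an aromatic carbon. Both measured steps touch the same position and run opposite ways: methyl in place of hydrogen gave a modest gain, carboxy in place of hydrogen a large loss. A hydroxy matches neither, so its step cannot be read off with confidence and should be taken as modest in either direction. Relative to compound 3, compound 4 is therefore expected to show a 1.5-fold higher number from compound 3 to compound 4 (0.18 log units; within the scatter), with an estimate of 60 nM and a range from 15 nM to 300 nM.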

Compound 4, inhibition constant: 22 nM
Beside the measured number, compound 4's estimate is 2.7-fold (0.44 log units) above it, within the range that was stated.
By their numbers in this assay, from the lowest: compound 1; then compounds 4 and 3 (each within the scatter of the next); then compound 2.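

In this assay, the change from phenyl to 4-hydroxyphenyl gives a 1.8-fold lower number from compound 3 to compound 4 (0.26 log units; within the scatter), so this hydroxy cannot be told apart from hydrogen at this place. The large loss seen with carboxy therefore does not extend to hydroxy, which shows a 45-fold lower number from compound 2 to compound 4 (1.66 log units; beyond the scatter), while methyl keeps an edge, with a 2.2-fold higher number from compound 1 to compound 4 (0.34 log units; beyond the scatter). No evidence is available to explain these steps. The compounds shown leave open how an amine, a methoxy group or a longer chain would behave at this place. They also leave open whether the large loss is particular to the carboxylic acid.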